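The source may hold more compounds than are shown below. What is called first, only, known or untested is meant among the compounds shown, and "the series" means these compounds.

The three measured compounds and their values in a functional assay on QGY7701 cells (Homo sapiens) for cytotoxicity, read by MTT assay, with a stated time of 24 h; a lower number here means a stronger inhibitor, a higher number a weaker inhibitor:

compound 1, `C=CC1=C(C(=O)NCc2ccc(Cl)cc2)C(c2ccc(OC)cc2)OC1`, > 100000 nM
compound 2, `C=CC1=C(C(=O)NCc2ccc(C)cc2)C(c2ccc(OC)cc2)OC1`, 43100 nM
compound 3, `C=CC1=C(C(=O)Nc2ccc(C)cc2)C(c2ccc(OC)cc2)OC1`, > 100000 nM

Compound 3 gives only a limit in this assay, not a number. Compound 1 sits at the same limit, as noted in the limit of > 100000 nM in this assay, at which 2 of the 3 values shown sit, so among the three only compound 2 yields a measured number. Among the compounds with values here, the one readable step is an at least 2.3-fold higher number from compound 2 to compound 3 (0.36 log units; beyond the scatter), and there is also an at least 2.3-fold lower number from compound 1 to compound 2 (0.36 log units; beyond the scatter); the pair of compound 1 and compound 3 is a step that the two limits leave unreadable from compound 1 to compound 3.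

Compound 4, `C=CC1=C(C(=O)Nc2ccccc2)C(c2ccc(OC)cc2)OC1`, differs from compound 3 by hydrogen in place of methyl on an aromatic carbon. Within the data shown here, none of the measured steps touches this change: the step from compound 1 to compound 2 swaps chloro for methyl on a benzyl ring, and the step from compound 2 to compound 3 changes the spacer to the amide nitrogen, not the substituent on the aromatic ring. The available steps therefore give no direction for compound 4, and since compound 3 stands at the limit, the expectation is that compound 4 likewise stays at or near that limit, with a step that the limit leaves unreadable from compound 3 to compound 4 expected. Compound 4 is estimated at 120000 nM, ranging from 40000 nM to 400000 nM.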

Compound 4, half-maximal inhibitory concentration: > 100000 nM
Compound 4: a limit, no number; the forecaster's own chance of this, stated with the estimate: 70%; the middle value lies beyond the limit too.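

In this assay compound 4 gives > 100000 nM, which is a limit and not a number. Taking the methyl off the aromatic carbon para to a large group thus brings no measured number: with 4-methylphenyl or with phenyl on the amide nitrogen the series stays at this limit, and the one readable new step, which sets phenyl in place of 4-methylbenzyl, is an at least 2.3-fold higher number from compound 2 to compound 4 (0.36 log units; beyond the scatter). The steps to compound 4 from compound 3 and from compound 1 cannot be read, because both ends of each stand at the same limit: the limit of > 100000 nM in this assay, at which 3 of the 4 values shown sit.

As far as these compounds go, whether hydrogen and methyl at this carbon differ at all stays open, with neither compound 3 nor compound 4 giving a number. Also open, from the compounds shown here alone, is whether an amine or a carboxylic acid at this carbon, or an unsubstituted benzyl group on the amide nitrogen, would give a number below the limit in this assay.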